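This account rests on a few compounds, and the source may have more. Where it says the series, first, only, none or still open, it means among the compounds named here.

Measured so far:
compound 1 `O=C1C(=O)N(CCCCCn2cc(COc3cc(=O)oc4ccccc34)nn2)c2ccccc21`, 69%
compound 2 `O=C1C(=O)N(CCCCn2cc(COc3cc(=O)oc4ccccc34)nn2)c2ccc(Cl)cc21`, 71%
compound 3 `COc1ccc2c(c1)C(=O)C(=O)N2CCCn1cc(COc2cc(=O)oc3ccccc23)nn1`, 56%

In a functional assay on THP-1 cells (Homo sapiens) for inhibition, read by sulforhodamine B assay, with a stated time of 48 h, tested at 50 uM (a higher number here means more inhibition of growth at the concentration tested, a lower number less inhibition of growth), compound 2 gives 71%, the highest of the three numbers. Compound 1 sits within the usual scatter of it, so the two cannot be told apart; compound 3 lies lower, and its gap to compound 2 is beyond the scatter. Compound 4 `COc1ccc2c(c1)C(=O)C(=O)N2CCCCn1cc(COc2cc(=O)oc3ccccc23)nn1` has not been tested in this assay. It differs from compound 2 in one place: methoxy in place of chloro on an aromatic carbon. For the measured compounds named here, no pair of measured compounds differs from each other by exactly this change, so the size of such a step in this assay is not known from the data. Going by the values given here, compound 3 also carries a methoxy group, but differs from compound 2 in more than one place, so its lower value shows only that a methoxy-bearing compound can sit below compound 2. The step expected here is a modest fall, a number 9 percentage points lower from compound 2 to compound 4 (within the scatter), perhaps at the edge of the scatter. Compound 4 is therefore estimated at 62%, in a range from 48% to 74%.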

Compound 4, percent growth inhibition at one concentration: 52%
Compound 4: the middle estimate sits 10 percentage points above what was measured; low and high end bracket the measured number.
By their numbers in this assay, from the lowest: compounds 4 and 3 (each within the scatter of the next); then compounds 1 and 2 (each within the scatter of the next).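

In this assay, for the compounds shown here, putting methoxy in place of chloro on this aromatic carbon, with the rest of the structure unchanged, gives a number 19 percentage points lower from compound 2 to compound 4 (beyond the scatter) and provides the first direct reading of this change. Going by these compounds alone, no two of the earlier compounds differed in only one place, so they could not separate the effect of this position from that of other parts of the structures. This pair shows that growth inhibition at the tested concentration can change with the group on this carbon, although no measurement here explains why the number falls.

From the compounds shown here alone, whether an amine, a carboxylic acid or fluoro on the same carbon would give a number closer to that of compound 2 or compound 4 remains open. Going by these compounds, it is also open whether this step would keep its size in a compound with a longer chain.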